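A few compounds are considered here, and "the series" means these few. Any claim that something is new, unique, unknown or untested is made for them only; others in the source may bear on it.

Working notes on the series. Compound 1 `S=C(Nc1ccccc1)N1N=C(c2ccccc2)CC1c1ccc2c(c1)OCCO2` carries an unsubstituted phenyl on the shared core; compound 2 `Fc1ccc(C2=NN(C(=S)Nc3ccccc3)C(c3ccc4c(c3)OCCO4)C2)cc1` differs from it by fluoro in place of hydrogen on an aromatic carbon. In a functional assay on HCT-116 cells (Homo sapiens) for antiproliferative activity, read by MTT assay, with a stated time of 48 h (on this read-out higher numbers stand for weaker inhibition of growth and lower numbers for stronger inhibition of growth), compound 1 gives 57600 nM, and in this assay compound 2 gives 61200 nM. The step of a 1.1-fold higher number from compound 1 to compound 2 (0.03 log units; within the scatter) separates the two. Among the measured compounds shown here, on the numbers so far compound 2 stands highest of the two, with compound 1 nearest to it, the gap being within the scatter, so neither can be called weaker or stronger than the other.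

Compound 3 `S=C(Nc1ccccc1)N1N=C(c2ccc(Cl)cc2)CC1c1ccc2c(c1)OCCO2` is the next member. The change from compound 2 is chloro in place of fluoro on an aromatic carbon. For the measured compounds named here, the only measured step that touches this position is the one from compound 1 to compound 2, which was within the scatter, and it says nothing directly about chloro. Given that a change at this aromatic carbon left this assay unmoved once, the expected step is a 1.1-fold lower number from compound 2 to compound 3 (0.05 log units; within the scatter), none beyond the scatter. The estimate for compound 3 in this assay is therefore 55000 nM, with a range from 25000 nM to 120000 nM.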

Compound 3, concentration for 50% growth inhibition: > 200000 nM
Compound 3 ended at the assay's limit (the forecaster's own chance of this, stated with the estimate: 10%); middle value at least 3.6-fold (0.56 log units) away from the limit.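

Working from this result, this aromatic carbon no longer looks indifferent: in this assay chloro in place of fluoro gives an at least 3.2-fold higher number from compound 2 to compound 3 (0.51 log units; beyond the scatter) and chloro in place of hydrogen gives an at least 3.4-fold higher number from compound 1 to compound 3 (0.54 log units; beyond the scatter) where fluoro in place of hydrogen gave only a 1.1-fold higher number from compound 1 to compound 2 (0.03 log units; within the scatter) and so left the assay unmoved. Compound 3 stands at a limit of the assay and not at a number, so both new steps give only a lower bound on their size: the limit of > 200000 nM in this assay, at which 1 of the 3 values shown sits. The earlier pair showed no response at this carbon, whereas the change from 4-fluorophenyl to 4-chlorophenyl shows that the identity of the group placed here matters, with compound 3 on the side of weaker inhibition of growth.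

From the compounds shown here alone, how far compound 3 lies past the limit remains unknown, and three members at one carbon give no trend across hydrogen, fluoro and chloro. Going by these compounds, whether the weakening belongs to chloro alone or extends to other groups at this carbon, such as bromo, methoxy or an amine, also remains open.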